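The source may report more compounds than this note shows. Statements on the series, on what has been measured and on what is new or still open speak of the compounds shown alone.

In a functional assay on B16 cells (Mus musculus) for cytotoxicity, read by CCK-8 assay, with a stated time of 24 h (a lower number here means a stronger inhibitor, a higher number a weaker inhibitor), compound 1 (`COc1ccccc1Oc1c(N)nc(-c2ccccc2)nc1Cl`) gives 4610 nM, compound 2 (`COc1ccccc1Oc1c(N)nc(-c2cccc(Br)c2)nc1Cl`) gives 24600 nM and compound 3 (`COc1ccccc1Oc1c(N)nc(-c2ccccc2)nc1OCCO`) gives 31100 nM. Compound 3 has the highest number of the three, although its value lies within the scatter of the value for compound 2. Compound 4 (`COc1ccccc1Oc1c(N)nc(-c2ccccc2F)nc1OCCO`) carries fluoro in place of hydrogen on an aromatic carbon, ortho to a large group: fluoro in place of hydrogen on an aromatic carbon. The closest measured change is bromo in place of hydrogen on an aromatic carbon, a 5.3-fold higher number from compound 1 to compound 2 (0.73 log units; beyond the scatter), a modest step. The change of chloro to 2-hydroxyethoxy, a 6.7-fold higher number from compound 1 to compound 3 (0.83 log units; beyond the scatter), is also modest but concerns a different group. For the measured compounds named here, no fluoro compound has been measured, so no step beyond the scatter is expected. The expected step is a 1.0-fold lower number from compound 3 to compound 4 (0.02 log units; within the scatter). For compound 4 the estimated value is 30000 nM, with an expected range from 11000 nM to 75000 nM.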

Compound 4, half-maximal inhibitory concentration: 11800 nM
Estimate against measurement, compound 4: 2.5-fold (0.41 log units) above; the measured number falls inside the stated range.
By their numbers in this assay, from the lowest: compound 1; then compound 4; then compounds 2 and 3 (each within the scatter of the next).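

In this assay, adding a single fluoro to the phenyl, ortho to a large group, gives a 2.6-fold lower number from compound 3 to compound 4 (0.42 log units; beyond the scatter), so even one added heavy atom at this place changes the number beyond the scatter. The only other phenyl change shown, bromo, moved the number the other way, a 5.3-fold higher number from compound 1 to compound 2 (0.73 log units; beyond the scatter), though on a chloro compound rather than a 2-hydroxyethoxy one. No measurement at hand explains why fluoro has this effect.

On these data alone, whether fluoro would give a similar step alongside the chloro of compound 1 remains open. So does the effect of a methoxy or an amine at this same place.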